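The source may report more compounds than this note shows. Statements on the series, on what has been measured and on what is new or still open speak of the compounds shown alone.

Series notes. Compound 1 `FC(F)(F)c1ccc(COc2cccc(Nc3ncnc4cc5c(cc34)OCCOCCOCCOCCO5)c2)cc1` and compound 2 `O=[N+]([O-])c1ccc(COc2cccc(Nc3ncnc4cc5c(cc34)OCCOCCOCCOCCO5)c2)cc1` share one core; compound 3 `FC(F)(F)c1ccc(COc2cccc(Nc3ncnc4cc5c(cc34)OCCOCCO5)c2)cc1` and compound 4 `O=[N+]([O-])c1ccc(COc2cccc(Nc3ncnc4cc5c(cc34)OCCOCCO5)c2)cc1` share another, and the difference between the two cores is not broken down here. In a functional assay on A549 cells (Homo sapiens) for antiproliferative activity, read by MTT assay, with a stated time of 72 h (on this read-out higher numbers stand for weaker inhibition and lower numbers for stronger inhibition), compound 1 gives 8520 nM. Compound 2 gives 19800 nM in this assay, and the change nitro in place of trifluoromethyl on an aromatic carbon makes the step of a 2.3-fold higher number from compound 1 to compound 2 (0.37 log units; beyond the scatter). Compound 3 in this assay gives only a limit, > 100000 nM, which is the limit of > 100000 nM in this assay, at which 1 of the 3 values shown sits. Compound 4 carries the same change, (nitro in place of trifluoromethyl on an aromatic carbon), on the second core. Compound 4 is expected to remain at or past that limit, with an expected step that the limit leaves unreadable from compound 3 to compound 4 that cannot be resolved better than a 2.3-fold higher number from compound 1 to compound 2 (0.37 log units; beyond the scatter) because compound 3 already sits at the limit of > 100000 nM in this assay, at which 1 of the 3 values shown sits. Compound 4 is therefore estimated at 200000 nM, with a range from 100000 nM to 600000 nM.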

Compound 4, half-maximal inhibitory concentration: 15500 nM
Compound 4: the middle estimate sits 13-fold (1.11 log units) above what was measured; measured number below the stated range.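

In this assay, nitro in place of trifluoromethyl gives an at least 6.4-fold lower number from compound 3 to compound 4 (0.80 log units; beyond the scatter), opposite in direction to the step on the other core, so the change does not carry over between these two cores: the same change on two cores in this assay, a 2.3-fold higher number (0.37 log units; beyond the scatter) from compound 1 to compound 2 and an at least 6.4-fold lower number (0.80 log units; beyond the scatter) from compound 3 to compound 4, at least 14-fold (1.17 log units) apart, beyond the scatter of two such steps

As far as these compounds go, for compound 3, > 100000 nM is a limit and not a number, so the true size of that step remains unknown. Two pairs set no rule for any further core and give no reason for the reversal.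

The compounds shown leave open whether a nitrile, a chlorine or a carboxylic acid in place of trifluoromethyl would follow the nitro pairs on either core.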